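Replacing pyridin-4-yl with 4-(trifluoromethyl)phenyl

This account rests on a few compounds, and the source may have more. Where it says the series, first, only, none or still open, it means among the compounds named here.

Measured so far in a functional assay on NCI-H1993 cells (Homo sapiens) for inhibition, read by CCK-8 assay, with a stated time of 72 h; a higher number here means a weaker inhibitor, a lower number a stronger inhibitor:

- compound 1 `c1cnc2ccc(Cn3cnc4ncc(-c5cn[nH]c5)nc43)cc2c1` gives 2890 nM
- compound 2 `Nc1ccc(-c2cnc3ncn(Cc4ccc5ncccc5c4)c3n2)cc1` gives 4950 nM
- compound 3 `c1cnc2ccc(Cn3cnc4ncc(-c5ccncc5)nc43)cc2c1` gives 1160 nM

Compound 3 has the lowest number of the three, and both of its steps lie beyond the scatter: a 2.5-fold lower number from compound 1 to compound 3 (0.40 log units; beyond the scatter) and a 4.3-fold lower number from compound 2 to compound 3 (0.63 log units; beyond the scatter). The remaining comparison, a 1.7-fold higher number from compound 1 to compound 2 (0.23 log units; within the scatter), stays within the scatter.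

Next in line is compound 4 `FC(F)(F)c1ccc(-c2cnc3ncn(Cc4ccc5ncccc5c4)c3n2)cc1`, which keeps the shared core and changes the group at the same site: 4-(trifluoromethyl)phenyl in place of pyridin-4-yl on an aromatic carbon. In words, this is 4-(trifluoromethyl)phenyl in place of pyridin-4-yl on an aromatic carbon.

Going by the values given here, the closest precedent is the step to compound 3 from compound 2, the only measured compound whose group has a ring of carbon only: a 4.3-fold lower number from compound 2 to compound 3 (0.63 log units; beyond the scatter). Read in reverse, it suggests a modest rise in the number on leaving pyridin-4-yl. Among the compounds with values here, no measured compound carries a trifluoromethyl group, so the size remains uncertain. The step expected in this assay is therefore upward and modest, estimated as a 3.0-fold higher number from compound 3 to compound 4 (0.48 log units; beyond the scatter). For compound 4 the expected value is 3500 nM, with an estimated range from 1300 nM to 9000 nM.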

Compound 4, half-maximal inhibitory concentration: > 10000 nM
Compound 4 ended at the assay's limit; the forecaster's own chance of this, stated with the estimate: 5%; middle value at least 2.8-fold (0.45 log units) away from the limit.
By their numbers in this assay, from the lowest: compound 3; then compounds 1 and 2 (each within the scatter of the next). At a limit, above all of these: compound 4.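

In this assay compound 4 gives > 10000 nM, which is a limit of the assay and not a number: the limit of > 10000 nM in this assay, at which 1 of the 4 values shown sits. The change at this aromatic carbon is therefore not confined to the modest shifts seen among the earlier groups: an at least 8.6-fold higher number from compound 3 to compound 4 (0.93 log units; beyond the scatter), and an at least 3.4-fold higher number from compound 1 to compound 4 (0.53 log units; beyond the scatter), so 4-(trifluoromethyl)phenyl reads clearly worse here than either of the two heteroaromatic groups. Against the other group with a ring of carbon only, the picture is less firm: an at least 2.0-fold higher number from compound 2 to compound 4 (0.30 log units; that floor lies within the scatter), so trifluoromethyl in place of amino on that ring cannot yet be called a real change in this assay.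

The compounds shown do not separate the effect of the trifluoromethyl group from that of leaving a ring with a hetero atom, and a plain phenyl or a 4-methoxyphenyl at this site would help to tell the two apart. As far as these compounds go, how a carboxylic acid or a morpholine on the same ring would read also stays open, as does the actual number for compound 4 beyond the limit.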